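The source may report more compounds than this note shows. Statements on the series, on what has been measured and on what is new or still open speak of the compounds shown alone.

Measured so far in a functional assay on MCF7 cells (Homo sapiens) for inhibition, read by fluorescence, with a stated time of 72 h (on this read-out higher numbers stand for weaker inhibition of growth and lower numbers for stronger inhibition of growth), for the three compounds:
Compound 1 `COc1ccc(Cn2cnc3c(Nc4cccc(Cl)c4)nc(N[C@H]4CC[C@H](N)CC4)nc32)cc1` gives 4800 nM
Compound 2 `CC(C)=CCn1cnc2c(Nc3cccc(Cl)c3)nc(N[C@H]3CC[C@H](N)CC3)nc21` gives 4200 nM
Compound 3 `CC(C)CCn1cnc2c(Nc3cccc(Cl)c3)nc(N[C@H]3CC[C@H](N)CC3)nc21` gives 2100 nM

Compound 3 separates only modestly from compound 1 (a 2.3-fold lower number from compound 1 to compound 3 (0.36 log units; beyond the scatter)) and not from compound 2 (a 2.0-fold lower number from compound 2 to compound 3 (0.30 log units; within the scatter)). The next molecule, compound 4 `CC(C)=CCC/C(C)=C/Cn1cnc2c(Nc3cccc(Cl)c3)nc(N[C@H]3CC[C@H](N)CC3)nc21`, has not yet been measured. Its difference from compound 3 is 2,6-dimethylhepta-1,5-dien-1-yl in place of isobutyl on a saturated chain carbon bound to an aromatic nitrogen and, cut one bond further out, the same change reads isopentyl to 3,7-dimethylocta-2,6-dien-1-yl.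

Among the compounds with values here, all the measured steps change the group at this same place, on a saturated chain carbon bound to an aromatic nitrogen. The remaining step (a 1.1-fold lower number from compound 1 to compound 2 (0.06 log units; within the scatter)) is small as well. Among these compounds, exchanging 4-methoxyphenyl, 2-methylprop-1-en-1-yl and isobutyl moved the number little. None of them carries a chain as long as the one entering here, so the data cannot rule out a larger move in either direction.

With compound 3 reached by only a modest step (a 2.3-fold lower number from compound 1 to compound 3 (0.36 log units; beyond the scatter)) no step beyond the scatter is expected in this assay and the estimated size is a 1.1-fold lower number from compound 3 to compound 4 (0.02 log units; within the scatter) for this change. The estimate for compound 4 is 2000 nM with an expected range from 700 nM to 5500 nM in this measurement.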

Compound 4, concentration for 50% growth inhibition: 3600 nM
The estimate for compound 4 lay 1.8-fold (0.26 log units) below the measured number; the range from low to high includes it.
By their numbers in this assay, from the lowest: compounds 3, 4, 2 and 1 (each within the scatter of the next, the first and the last beyond it).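

In this assay, the longest chain seen so far at this place, 2,6-dimethylhepta-1,5-dien-1-yl, gives a number that cannot be told apart from those of the three smaller groups: a 1.7-fold higher number from compound 3 to compound 4 (0.23 log units; within the scatter), a 1.2-fold lower number from compound 2 to compound 4 (0.07 log units; within the scatter) and a 1.3-fold lower number from compound 1 to compound 4 (0.12 log units; within the scatter). The earlier compounds shown here left open a larger move in either direction once a long chain entered, yet adding this much carbon and two double bonds on a saturated chain carbon bound to an aromatic nitrogen produced no step beyond the scatter in this comparison with any of the three. No supporting measurement is available to account for this flat result.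

The groups shown at this place are a 4-methoxyphenyl group and plain carbon chains, so it remains open whether an amine or a carboxylic acid at the end of the chain, or a chain longer still, would shift the number beyond the scatter. The rest of the molecule is also the same in all four compounds, so these results say nothing about how this place behaves on a different core.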